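Furan-3-yl for furan-2-yl beside an ethylsulfanyl carbonyl

A few compounds are considered here, and "the series" means these few. Any claim that something is new, unique, unknown or untested is made for them only; others in the source may bear on it.

Measured so far:
compound 1, `CCCC(=O)C1=C(C)NC(=O)NC1c1ccco1`, 1%
compound 2, `CCCC(=O)C1=C(C)NC(=O)NC1c1ccoc1`, 2%
compound 3, `CCSC(=O)C1=C(C)NC(=O)NC1c1ccco1`, 14%

In an assay on membranes from HeLa cells for displacement of a labelled ligand from adenosine receptor A3 (Homo sapiens), read by scintillation counting, with a stated time of 180 min, tested at 1 uM (on this read-out lower numbers stand for less inhibition and higher numbers for more inhibition at the one concentration tested (going by the name of the read-out)), compound 1 gives 1%. Compound 2 carries furan-3-yl in place of furan-2-yl on a saturated ring carbon; the step of a number 1 percentage points higher from compound 1 to compound 2 (within the scatter) lies within the scatter, so the two values are read as equal. Compound 3 carries ethylsulfanyl in place of propyl on a carbonyl carbon; here the step of a number 13 percentage points higher from compound 1 to compound 3 (beyond the scatter) lies beyond the scatter, and compound 3 stands highest of the three in this assay, with compound 2 and compound 1 both lower by more than the scatter.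

Compound 4, `CCSC(=O)C1=C(C)NC(=O)NC1c1ccoc1`, is not yet measured. It differs from compound 3 by furan-3-yl in place of furan-2-yl on a saturated ring carbon. The same change occurs twice among the compounds shown, once from compound 1 to compound 2 and once from compound 3 to compound 4. The two cores differ as described by ethylsulfanyl in place of propyl on a carbonyl carbon: in compound 1 the saturated ring carbon sits next to the ring atom that bears a propylcarbonyl group, in compound 3 next to the ring atom that bears a (ethylsulfanyl)carbonyl group, so the change is of the same kind but not the same.

For compound 4 in this assay a step of about the size of a number 1 percentage points higher from compound 1 to compound 2 (within the scatter) is expected, a step estimated as a number 1 percentage points higher from compound 3 to compound 4 (within the scatter), because the earlier one, a number 1 percentage points higher from compound 1 to compound 2 (within the scatter), stayed within the scatter. Compound 4 is therefore estimated at 15%, with a range from 5% to 28%; this rests on one prior step only.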

Compound 4, a percentage reported as inhibition, at one concentration (the size of the read-out at that concentration, not a potency): 1%
Compound 4: the middle estimate sits 14 percentage points above what was measured; measured number outside the range, below it.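

In this assay, furan-3-yl in place of furan-2-yl on a saturated ring carbon gives a number 13 percentage points lower from compound 3 to compound 4 (beyond the scatter), whereas the step on the propylcarbonyl core stayed within the scatter, yet the two steps cannot be told apart: the same change on two cores in this assay, a number 1 percentage points higher (within the scatter) from compound 1 to compound 2 and a number 13 percentage points lower (beyond the scatter) from compound 3 to compound 4, 14 percentage points apart, within the scatter of two such steps. Read the other way, ethylsulfanyl in place of propyl on a carbonyl carbon gives a number 13 percentage points higher from compound 1 to compound 3 (beyond the scatter) with furan-2-yl and a number 1 percentage points lower from compound 2 to compound 4 (within the scatter) with furan-3-yl, and this pair does not separate either: the same change on two cores in this assay, a number 13 percentage points higher (beyond the scatter) from compound 1 to compound 3 and a number 1 percentage points lower (within the scatter) from compound 2 to compound 4, 14 percentage points apart, within the scatter of two such steps. Among the compounds shown here, the data therefore give no firm sign that the furan change behaves differently on the two cores, but they do not show that it carries over unchanged, since each comparison rests on one pair of steps and the whole case turns on the single value of compound 3.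

From the compounds shown here alone, whether either step holds with another group on the carbonyl carbon, such as ethoxy or a longer alkylsulfanyl chain, remains open, as does whether phenyl or thiophen-2-yl on the saturated ring carbon would follow either furan. Going by these compounds, a percentage at one concentration gives no potency, so how these compounds would compare across a range of concentrations also remains open.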